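Swapping a Benzoyl Group for a Piperidine-Bearing Acyl Chain

The source may hold more compounds than are shown below. What is called first, only, known or untested is meant among the compounds shown, and "the series" means these compounds.

Of the compounds shown here, three have been measured in a functional assay on PC-3 cells (Homo sapiens) for cytotoxicity, read by MTT assay, with a stated time of 48 h; a lower number here means a stronger inhibitor, a higher number a weaker inhibitor. Compound 1 `CC1=NN(C(=O)c2ccc(C)cc2)C(c2cc(Br)cc(Br)c2O)C1` gives 41200 nM, and compound 2 `CC1=NN(C(=O)CN2CCC(c3ccccc3)CC2)C(c2ccccc2O)C1` gives 20400 nM. Compound 3 `O=C(c1ccccc1)N1N=C(c2cc3ccccc3oc2=O)CC1c1ccccc1`, built on a different core from the other two, gives 5870 nM, the lowest of the three numbers; its gap to compound 2 and its larger gap to compound 1 both lie beyond the scatter of this assay, so compound 3 stands as the strongest inhibitor among the measured set.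

Compound 4 `CC1CCCCN1CC(=O)N1N=C(c2cc3ccccc3oc2=O)CC1c1ccccc1` keeps the core of compound 3 and changes only the group on the carbonyl carbon: (2-methylpiperidin-1-yl)methyl in place of phenyl on a carbonyl carbon. For the measured compounds named here, no measured pair shows this change on this core, so the step is open. Compound 2, which carries a related acyl chain on another core, gives a weaker number than compound 3, but that comparison spans more than one change and cannot be read as a step.

The step of a 1.5-fold higher number from compound 3 to compound 4 (0.19 log units; within the scatter) is expected to be a modest weakening, possibly no larger than the scatter. Compound 4 is thus estimated at 9000 nM, within 3000 nM to 30000 nM.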

Compound 4, half-maximal inhibitory concentration: 36300 nM
The estimate for compound 4 lay 4.0-fold (0.61 log units) below the measured number; measured number above the stated range.
By their numbers in this assay, from the lowest: compound 3; then compounds 2, 4 and 1 (each within the scatter of the next, the first and the last beyond it).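

For the compounds shown here, this is the first measured step at the group on the carbonyl carbon, and it shows that this position on the shared core responds to what sits there. In this assay, (2-methylpiperidin-1-yl)methyl in place of phenyl gives a 6.2-fold higher number from compound 3 to compound 4 (0.79 log units; beyond the scatter), so on this core the benzoyl group cannot be exchanged for this acyl chain without a loss of strength. No evidence here bears on why the number rises.

A single step cannot separate losing the phenyl ring from gaining the ring nitrogen or the methyl group on the piperidine. A plain piperidin-1-ylmethyl, a morpholin-4-ylmethyl or a benzyl group on the same carbonyl carbon would begin to tell these apart.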